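This account rests on a few compounds, and the source may have more. Where it says the series, first, only, none or still open, it means among the compounds named here.

Values in a functional assay on J774 cells (Mus musculus) for cytotoxicity, read by resazurin assay, with a stated time of 72 h; on this read-out lower numbers stand for stronger inhibition and higher numbers for weaker inhibition:
compound 1 `O=S(=O)(Nc1ccc(CO)c(CO)c1)c1ccc(-c2ccc(F)cc2F)cc1` gives 150 nM;
compound 2 `O=S(=O)(Nc1cccc(CO)c1)c1ccc(-c2ccc(Br)cc2)cc1` gives 2500 nM;
compound 3 `O=S(=O)(Nc1ccc(CO)cc1)c1ccc(-c2ccc(Br)cc2)cc1` gives 3500 nM.

Compound 3 holds the highest number of the three, within the scatter of compound 2 and beyond it from compound 1. Compound 4 `O=S(=O)(Nc1ccc(CCO)cc1)c1ccc(-c2ccc(Br)cc2)cc1` differs from compound 3 by hydroxymethyl in place of hydroxy on a saturated chain carbon bound to an aromatic carbon. Going by the values given here, the only single-point step measured, a 1.4-fold higher number from compound 2 to compound 3 (0.15 log units; within the scatter), moves the hydroxymethyl group around the ring and says nothing about lengthening the chain; no step bears on this change. With nothing to draw on, no shift beyond the scatter is expected in this assay. Compound 4 is therefore estimated at 3500 nM, with a range of 1500 nM to 8000 nM. For compound 4 this expectation amounts to no change at the digits printed from compound 3 to compound 4 (within the scatter).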

Compound 4, half-maximal inhibitory concentration: 4500 nM
For compound 4 the middle estimate is 1.3-fold (0.11 log units) below the measured one; the measured number falls inside the stated range.
By their numbers in this assay, from the lowest: compound 1; then compounds 2, 3 and 4 (each within the scatter of the next).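

In this assay, going by these compounds alone, extending hydroxymethyl to 2-hydroxyethyl gives a 1.3-fold higher number from compound 3 to compound 4 (0.11 log units; within the scatter) as the first reading on chain length at this position, where the earlier compounds showed only a move of hydroxymethyl around the ring. This single change therefore shows no shift beyond the scatter. Nothing available bears on the reason for this result.

Going by these compounds, whether a longer chain, or an amine or a carboxylic acid in place of the hydroxy, would stay within the scatter remains open. Compound 1 differs from compound 2, compound 3 and compound 4 in more than one place, so its separate value cannot be assigned to any single change.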